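Indole-oxadiazoles in MIA PaCa-2 cytotoxicity: pyridyl to methyl

This account rests on a few compounds, and the source may have more. Where it says the series, first, only, none or still open, it means among the compounds named here.

Measured so far:
compound 1 `c1ccc2c(-c3nnc(-c4ccncc4)o3)c[nH]c2c1`, a functional assay on MIA PaCa-2 cells (Homo sapiens) for cytotoxicity, read by MTT assay (a lower number here means a stronger inhibitor, a higher number a weaker inhibitor), 1600 nM
compound 2 `c1cncc(-c2nnc(-c3c[nH]c4ccccc34)o2)c1`, this assay 900 nM

Within the data shown here, compound 2 gives the lower of the two numbers, but the only step, a 1.8-fold lower number from compound 1 to compound 2 (0.25 log units; within the scatter), lies within the scatter, so the two stand level. Compound 3 `Cc1nnc(-c2c[nH]c3ccccc23)o1` carries methyl in place of pyridin-3-yl on an aromatic carbon. Among the measured compounds shown here, no measured step bears on removing an aromatic ring from this position; the pyridyl swap is of a different kind. A weaker inhibitor is expected, a 5.6-fold higher number from compound 2 to compound 3 (0.74 log units; beyond the scatter), and compound 3 is estimated at 5000 nM (range 1500 nM to 20000 nM).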

Compound 3, half-maximal inhibitory concentration: 145000 nM
Compound 3: the middle estimate sits 29-fold (1.46 log units) below what was measured; measured number above the stated range.
By their numbers in this assay, from the lowest: compounds 2 and 1 (each within the scatter of the next); then compound 3.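

Methyl in place of a pyridyl group on this aromatic carbon gives a 160-fold higher number from compound 2 to compound 3 (2.21 log units; beyond the scatter) and a 91-fold higher number from compound 1 to compound 3 (1.96 log units; beyond the scatter) in this assay, whereas exchanging pyridin-4-yl for pyridin-3-yl stayed within the scatter. Across these three compounds, the number therefore depends far more on whether the six-membered aromatic ring is present than on where its ring nitrogen lies. No available evidence accounts for this loss. Still open, from the compounds shown here alone, is whether the ring nitrogen is needed at all, which phenyl would test. Also open, going by these compounds, is whether an n-butyl chain or a cyclopropyl group would recover part of the loss.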